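Chloro to fluoro exchange on the shared core

The compounds below may be only part of what the source reports. "The series", "measured", "known", "first", "only" and "open" are said of these compounds alone.

Compound 1 `N#Cc1c(F)c(F)c2nc(N)nc(N)c2c1F` reaches only a limit of a functional assay on A549 cells (Homo sapiens) for cytotoxicity, read by MTT assay (on this read-out higher numbers stand for weaker inhibition and lower numbers for stronger inhibition), and gives > 1000 ug/mL there. Compound 2 `N#Cc1c(NCc2ccccc2)c(F)c2nc(N)nc(N)c2c1F` likewise stops at the limit, > 1000 ug/mL in this assay. The step that the two limits leave unreadable from compound 1 to compound 2 thus cannot be read. Within the data shown here, compound 3 `CC(C)(C)Nc1c(C#N)c(F)c2c(N)nc(N)nc2c1Cl` gives 313 ug/mL in this assay and is the one compound of the three with a number rather than a limit; the other two rest on (the limit of > 1000 ug/mL in this assay, at which 2 of the 3 values shown sit). Compound 4 `CC(C)(C)Nc1c(C#N)c(F)c2c(N)nc(N)nc2c1F` differs from compound 3 in a single place: fluoro in place of chloro on an aromatic carbon. Among the measured compounds shown here, no measured pair traces this exchange, and the sole measured step, from a fluoro to a benzylamino group, is unreadable between two limits. An exchange of two halogens of one heavy atom each on the same aromatic carbon gives no basis for expecting a move beyond the scatter in this assay. Compound 4 is therefore estimated at 400 ug/mL, within 150 ug/mL to 1000 ug/mL, which means an expected step of a 1.3-fold higher number from compound 3 to compound 4 (0.11 log units; within the scatter) of no size beyond the scatter.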

Compound 4, half-maximal inhibitory concentration: > 1000 ug/mL
Compound 4: only a limit was reported; the forecaster's own chance of this, stated with the estimate: 25%; middle value at least 2.5-fold (0.39 log units) from the limit.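

In this assay, among these compounds, fluoro in place of chloro on this aromatic carbon, ortho to the (tert-butyl)amino group, gives an at least 3.1-fold higher number from compound 3 to compound 4 (0.50 log units; beyond the scatter), the only readable step and one beyond the scatter. This position therefore responds to an exchange of one halogen for another, and in this pair chloro alone separates a compound with a number from one at a limit. The steps from compound 1 and compound 2 to compound 4 cannot be read, and compound 3 remains the only compound with a number: the limit of > 1000 ug/mL in this assay, at which 3 of the 4 values shown sit.

Going by these compounds, how far compound 4 lies past its limit remains open, so the step has a minimum size only. Also open, on these data alone, is whether a bromo or methyl group on this aromatic carbon would give a number, as chloro does.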